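Removing the N-Aryl Group from the Chloro Core

A few compounds are considered here, and "the series" means these few. Any claim that something is new, unique, unknown or untested is made for them only; others in the source may bear on it.

Compound 1 `COc1ncc(-c2ccc3c(c2)NC(=O)CO3)cc1NS(=O)(=O)c1ccc(F)cc1`: 26300 nM.
Compound 2 `COc1ncc(-c2ccc3c(c2)N(c2ccc(F)cc2)C(=O)CO3)cc1NS(=O)(=O)c1ccc(F)cc1`: a limit of the assay, > 40000 nM.
Compound 3 `O=C1COc2ccc(-c3cnc(Cl)c(NS(=O)(=O)c4ccc(F)cc4)c3)cc2N1c1ccc(F)cc1`: a limit of the assay, > 40000 nM.

In a functional assay on A-375 cells (Homo sapiens) for antiproliferative activity, read by MTT assay, with a stated time of 72 h (on this read-out lower numbers stand for stronger inhibition and higher numbers for weaker inhibition), compound 1 gives 26300 nM. For compound 2 the result is only a limit of the assay, > 40000 nM. For compound 3 the result is likewise only a limit, > 40000 nM. Compound 1 differs from compound 2 by hydrogen in place of 4-fluorophenyl on an amide-type nitrogen in a ring, and that step is an at least 1.5-fold lower number from compound 2 to compound 1 (0.18 log units; that floor lies within the scatter). The two cores differ by chloro in place of methoxy on an aromatic carbon; that step is a step that the two limits leave unreadable from compound 2 to compound 3 because of the limit of > 40000 nM in this assay, at which 2 of the 3 values shown sit.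

Compound 4 `O=C1COc2ccc(-c3cnc(Cl)c(NS(=O)(=O)c4ccc(F)cc4)c3)cc2N1` has not yet been measured. Among the measured compounds shown here, it differs from compound 3 by hydrogen in place of 4-fluorophenyl on an amide-type nitrogen in a ring, which is the same change as the one from compound 2 to compound 1. Because the earlier step was an at least 1.5-fold lower number from compound 2 to compound 1 (0.18 log units; that floor lies within the scatter), a step of about an at least 1.3-fold lower number from compound 3 to compound 4 (0.12 log units; that floor lies within the scatter) is expected for compound 4 in this assay. Since compound 3 is known only as a limit, the starting point is itself uncertain. Compound 4 is therefore estimated at 30000 nM in this assay, most likely between 12000 nM and 60000 nM.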

Compound 4, half-maximal inhibitory concentration: > 40000 nM
Compound 4: no number, only a limit; the forecaster's own chance of this, stated with the estimate: 40%; at least 1.3-fold (0.12 log units) between middle value and limit.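

In this assay compound 4 gives only a limit of the assay, > 40000 nM. The step from 4-fluorophenyl to hydrogen on the chloro core therefore has no readable size, and neither that step nor the change from methoxy to chloro between the two N-aryl compounds can be read: the limit of > 40000 nM in this assay, at which 3 of the 4 values shown sit. Among the compounds shown here, the one new step that can be read is chloro in place of methoxy on an aromatic carbon, an at least 1.5-fold higher number from compound 1 to compound 4 (0.18 log units; that floor lies within the scatter), so the data neither show that the change to hydrogen carries over from the methoxy core to the chloro core nor show that it fails to.

Of the compounds shown, only compound 1 has a measured number, which leaves open whether any other group on the amide-type nitrogen, such as a carboxylic acid or a longer chain ending in an amine, would give a measurable value in this assay. Going by these compounds, it also remains open how an amine in place of methoxy or chloro on that aromatic carbon would read in this assay.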